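A few compounds are considered here, and "the series" means these few. Any claim that something is new, unique, unknown or untested is made for them only; others in the source may bear on it.

Compound 2 `CC1=C(C(=O)OCC(F)(F)F)C(c2cccs2)NC(=O)N1` gives 1% in an assay on HeLa cells for displacement of a labelled ligand from adenosine receptor A3 (Homo sapiens), read by radioligand binding, with a stated time of 180 min, tested at 1 uM (on this read-out lower numbers stand for less inhibition and higher numbers for more inhibition at the one concentration tested (going by the name of the read-out)), level at the digits shown with compound 1 `CC1=C(C(=O)OCC(F)(F)F)C(c2ccoc2)NC(=O)N1`, which gives 1%. Compound 3 `CC1=C(C(=O)OCC(F)(F)F)C(c2ccco2)NC(=O)N1` differs from compound 2 as follows: furan-2-yl in place of thiophen-2-yl on a saturated ring carbon. Within the data shown here, the one measured step that bears on this change is no change at the digits printed from compound 1 to compound 2 (within the scatter), an exchange of one five-membered aromatic ring with one hetero atom for another that left the inhibition unchanged within the scatter. Compound 3 is therefore expected to show a step of no change at the digits printed from compound 2 to compound 3 (within the scatter), nothing beyond the scatter. The estimate for compound 3 is 1%, with a range from -9% to 11%.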

Compound 3, a percentage reported as inhibition, at one concentration (the size of the read-out at that concentration, not a potency): 1%
For compound 3 middle estimate and measured number coincide at the digits printed; low and high end bracket the measured number.
By their numbers in this assay, from the lowest: compounds 1, 2 and 3 (each within the scatter of the next).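

Read in this assay, the change from thiophen-2-yl to furan-2-yl gives no change at the digits printed from compound 2 to compound 3 (within the scatter) and the move from furan-3-yl to furan-2-yl gives no change at the digits printed from compound 1 to compound 3 (within the scatter) at this saturated ring carbon. The second step adds what the earlier pair lacked: two furan rings attached differently, which read the same here. No supporting data offer an explanation for this result.

From the compounds shown here alone, whether this position can raise the inhibition at all remains open. A phenyl ring, an amine or a carboxylic acid at this carbon might answer that.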